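The compounds below may be only part of what the source reports. "The series", "measured", "known", "first", "only" and "open" are said of these compounds alone.

Of the compounds shown here, three have been measured so far in a physicochemical assay for solubility, in phosphate buffer, with a stated time of 18 h; a lower number here means a less soluble compound, a higher number a more soluble compound. Compound 1 `CC(C)(C)c1ccc2c(N)c(C#N)c(N)nc2n1` gives 14200 nM, compound 2 `N#Cc1c(N)nc2nc(Cc3ccccc3)ncc2c1N` gives 13000 nM and compound 3 `Cc1nc(C(C)(C)C)nc2nc(N)c(C#N)c(N)c12` gives 37000 nM. Compound 3 stands highest of the three, and its gaps to compound 1 and to compound 2 both lie beyond the usual scatter.

Compound 4 `CC(C)(C)c1nc(-c2cccs2)c2c(N)c(C#N)c(N)nc2n1` carries thiophen-2-yl in place of the methyl of compound 3 on an aromatic carbon: thiophen-2-yl in place of methyl on an aromatic carbon. For the measured compounds named here, no two measured compounds differ in one place only, so the series offers no direct measure of this change, and the expectation rests on the structural change alone. Starting from compound 3 at 37000 nM, a moderate fall in this assay, beyond the scatter, is expected. The expected step is a 4.1-fold lower number from compound 3 to compound 4 (0.61 log units; beyond the scatter). Compound 4 is expected at 9000 nM, with an estimated range from 2500 nM to 28000 nM.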

Compound 4, solubility: 56000 nM
Compound 4: the middle estimate sits 6.2-fold (0.79 log units) below what was measured; measured number outside the range, above it.
By their numbers in this assay, from the lowest: compounds 2 and 1 (each within the scatter of the next); then compounds 3 and 4 (each within the scatter of the next).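

For the compounds shown here, at this aromatic carbon, next to the ring nitrogen, thiophen-2-yl in place of methyl gives a 1.5-fold higher number from compound 3 to compound 4 (0.18 log units; within the scatter) in this assay, the first step that can be read at a single place. Exchanging methyl, with 1 heavy atom, for a five-membered aromatic ring with 5 heavy atoms therefore leaves the read-out within the scatter, and the two compounds cannot be ordered. Nothing at hand bears on the reason for this.

As far as these compounds go, this single step comes from one pair, both members carrying the tert-butyl group, so it is open whether it would hold with another group in that place. Also open, from the compounds shown here alone, is how an amine, a morpholine or a carboxylic acid on the same aromatic carbon would read in this assay.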